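Shifting a fluorine: from compound 2 to compound 3

The source may report more compounds than this note shows. Statements on the series, on what has been measured and on what is new or still open speak of the compounds shown alone.

compound 1 `O=C(N/N=C/c1ccccc1)c1cccnc1Nc1cccc(C(F)(F)F)c1` — 36.8%
compound 2 `O=C(N/N=C/c1cccc(F)c1)c1cccnc1Nc1cccc(C(F)(F)F)c1` — 52.8%

In a functional assay on the whole organism (strain Wistar) for inhibition, with Rattus norvegicus as the target, read by paw edema, with a stated time of 2 h, at a dose of 10 mg/kg by the intraperitoneal route (on this read-out lower numbers stand for less inhibition and higher numbers for more inhibition at the one dose given (going by the name of the read-out)), compound 1 gives 36.8%, and compound 2 gives 52.8%. Within the data shown here, the one step measured so far is a number 16 percentage points higher from compound 1 to compound 2 (beyond the scatter), fluoro in place of hydrogen on an aromatic carbon. Compound 2 thus stands highest of the two numbers, with compound 1 as its nearest neighbour, lower by that step.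

Compound 3 `O=C(N/N=C/c1ccc(F)cc1)c1cccnc1Nc1cccc(C(F)(F)F)c1` differs from compound 2 by 4-fluorophenyl in place of 3-fluorophenyl on a carbon with a double bond to nitrogen. The measured step concerned adding a fluorine, not moving one, so it bears only loosely on this change; it shows that the fluorine matters to the read-out, but not where on the ring it should sit. No step beyond the scatter is expected, only a mild drift, with a number 2.8 percentage points lower from compound 2 to compound 3 (within the scatter) as the expected step. Compound 3 is therefore estimated at 50%, ranging from 35% to 65%.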

Compound 3, a percentage reported as inhibition, in the whole organism at one dose (the size of the read-out at that dose, not a potency): 41.2%
The estimate for compound 3 lay 8.8 percentage points above the measured number, within the range that was stated.
By their numbers in this assay, from the lowest: compounds 1 and 3 (each within the scatter of the next); then compound 2.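

In this assay, the place of the fluorine on this ring counts, not only its presence: 4-fluorophenyl in place of 3-fluorophenyl on a carbon with a double bond to nitrogen gives a number 11.6 percentage points lower from compound 2 to compound 3 (beyond the scatter) and so separates two compounds with the same atoms. Fluoro in place of hydrogen also no longer reads as one general gain, since a number 4.4 percentage points higher from compound 1 to compound 3 (within the scatter) stands against the earlier a number 16 percentage points higher from compound 1 to compound 2 (beyond the scatter) for the other placement. No measurement is at hand that would explain this difference between the two placements.

On these data alone, it remains open whether a group other than fluoro, such as methoxy, an amine or a carboxylic acid, would respond to placement on this ring in the same way. Also open, as far as these compounds go, is how the read-out would change with a longer chain in place of the trifluoromethyl on the shared core.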